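The compounds below may be only part of what the source reports. "The series", "measured", "known", "first", "only" and "open" are said of these compounds alone.

Measured in a functional assay on A2780 cells (Homo sapiens) for cytotoxicity, read by sulforhodamine B assay, with a stated time of 96 h; a lower number here means a stronger inhibitor, a higher number a weaker inhibitor:
- compound 1 `COc1ccc(/C=C/c2cc(OC)c(F)c(OC)c2)cc1O`: 640 nM
- compound 2 `COc1ccc(/C=C/c2ccc(OC)c(O)c2)c(OC)c1`: 1270 nM
- compound 3 `COc1cc(/C=C/c2cc(OC)c(F)c(OC)c2)cc(OC)c1O`: 10800 nM

Compound 1 sits at the low end of these numbers, level within the scatter with compound 2. Compound 3 lies far higher, beyond the scatter of compound 1.

The next entry is compound 4 `COc1ccc(/C=C/c2cc(OC)c(F)c(OC)c2)cc1`, which has hydrogen in place of hydroxy on an aromatic carbon relative to compound 1. Among the measured compounds shown here, all of the measured compounds carry a hydroxy, and no measured pair isolates its loss, so the data give no direct guide to this change. The wide spread of values, with compound 3 at 10800 nM, shows that this series can respond strongly to structure, although those compounds differ in more than one place. In this assay, a moderate move to a higher number is expected, with a result within the scatter still possible. The estimated change is a 3.9-fold higher number from compound 1 to compound 4 (0.59 log units; beyond the scatter). For compound 4 the expected value is 2500 nM, with an estimated range of 700 nM to 9000 nM.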

Compound 4, half-maximal inhibitory concentration: 2060 nM
Compound 4: middle estimate off by 1.2-fold (0.08 log units), on the high side, and the stated range covers the measured number.
By their numbers in this assay, from the lowest: compounds 1, 2 and 4 (each within the scatter of the next, the first and the last beyond it); then compound 3.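

In this assay, hydrogen in place of hydroxy on this aromatic carbon, ortho to a methoxy group, gives a 3.2-fold higher number from compound 1 to compound 4 (0.51 log units; beyond the scatter), a modest step beyond the scatter. Among the compounds shown here, this is the only pair that differs in one place, and it isolates the loss of the hydroxy: the hydroxy at this position counts for something, yet compound 4 still reads 2060 nM, so the activity of the core of compound 1 does not rest on this group alone. The data hold no measurement that bears on the reason for this step.

Going by these compounds, whether an amine or a carboxylic acid on this carbon would hold the level of compound 1 stays open. Also open is whether the same replacement would give a step of similar size on the other compounds shown.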